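The source may hold more compounds than are shown below. What is called first, only, known or untested is meant among the compounds shown, and "the series" means these compounds.

Within the data shown here, compound 1 `O=C(Nc1cccc(-n2cc(-c3ccncc3)c(-c3ccc(Cl)c(O)c3)n2)c1)Nc1ccc(Cl)c(Cl)c1` is the only compound with a number in a functional assay on CAKI-1 cells (Homo sapiens) for inhibition, read by sulforhodamine B assay, with a stated time of 48 h; on this read-out lower numbers stand for stronger inhibition of growth and higher numbers for weaker inhibition of growth; in this assay compound 1 gives 14300 nM. Compound 2 `COc1cc(-c2nn(-c3cccc(NC(=O)c4ccccc4)c3)cc2-c2ccncc2)ccc1Cl` returns only a limit of the assay, > 100000 nM, and the limit of > 100000 nM in this assay, at which 1 of the 2 values shown sits, records that one of the two values sits at it. Compound 3 `O=C(Nc1cccc(-n2cc(-c3ccncc3)c(-c3ccc(Cl)c(O)c3)n2)c1)Nc1ccc(Cl)c(C(F)(F)F)c1` differs from compound 1 by trifluoromethyl in place of chloro on an aromatic carbon. Among the measured compounds shown here, no measured step covers this change, so the step is expected to be small, at most a modest gain and possibly none beyond the scatter; the estimated step is a 1.4-fold lower number from compound 1 to compound 3 (0.16 log units; within the scatter). Compound 3 is expected to give 10000 nM, within 3000 nM to 40000 nM.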

Compound 3, concentration for total growth inhibition: 2630 nM
The estimate for compound 3 lay 3.8-fold (0.58 log units) above the measured number; measured number below the stated range.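

In this assay, going from 3,4-dichlorophenyl to 4-chloro-3-(trifluoromethyl)phenyl gives a 5.4-fold lower number from compound 1 to compound 3 (0.74 log units; beyond the scatter). This first step at the position lies beyond the scatter, so the aromatic carbon ortho to a chloro group is sensitive to the group it carries. Nothing shown accounts for the size of this step.

On these data alone, whether other groups on this carbon, such as a nitrile, a methoxy group or an amine, would match trifluoromethyl remains open. Also open, as far as these compounds go, is whether the step would hold with the other chloro group replaced.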